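Isopropyl for Chloro on an Aryl Ether Side Chain

The compounds below may be only part of what the source reports. "The series", "measured", "known", "first", "only" and "open" are said of these compounds alone.

The series shares a core carrying an ether-linked side chain that ends in a substituted benzene ring. Compound 1 `CCn1c(=O)[nH]c2ccc(OCCOc3ccc(C(C)C)cc3)cc21` was tested in an assay on cells for inhibition of Amine oxidase [flavin-containing] A (Homo sapiens), read by fluorescence, with stated times of 30 min and 15 min; on this read-out lower numbers stand for stronger inhibition and higher numbers for weaker inhibition. In this assay compound 1 gives > 500000 nM, which is a limit of the assay and not a number. Compound 2 `CC(C)n1c(=O)[nH]c2ccc(OCCOc3ccc(Cl)cc3)cc21` carries a chloro group on the terminal ring and an isopropyl group on the core; for compound 2 the result in this assay is "not determined" (no result reported), so no number places it anywhere. The only fixed point in the set is therefore (the limit of > 500000 nM in this assay, at which 1 of the 2 values shown sits).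

Compound 3 `CC(C)c1ccc(OCCOc2ccc3[nH]c(=O)n(C(C)C)c3c2)cc1` differs from compound 2 in a single place: isopropyl in place of chloro on an aromatic carbon. Among the measured compounds shown here, no measured step between two compounds is available, so the size and direction of this change cannot be read from the data. Given that compound 1, which carries the same isopropyl-substituted ring, sits at > 500000 nM, compound 3 is expected to show weak inhibition as well, with an estimated value of 400000 nM in a range from 50000 nM to 1000000 nM, and a substantial chance that the assay again reports only a limit.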

Compound 3, half-maximal inhibitory concentration: > 500000 nM
Compound 3: only a limit was reported; the forecaster's own chance of this, stated with the estimate: 70%; middle value at least 1.2-fold (0.09 log units) away from the limit.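

In this assay compound 3 gives > 500000 nM, a limit of the assay and not a number. Among the compounds shown here, compound 1 also stands only at a limit and compound 2 offers no number, so no step to compound 3 can be read from either. The compounds shown leave open whether isopropyl or chloro on the terminal ring makes any difference to inhibition.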